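Swapping the Sulfonyl Aryl Group on a Shared Amide Core

The compounds below may be only part of what the source reports. "The series", "measured", "known", "first", "only" and "open" are said of these compounds alone.

Of the compounds shown here, two on a shared core have been measured in a functional assay on CHO cells for positive allosteric modulation of muscarinic acetylcholine receptor M5 (Homo sapiens), read by calcium flux; a lower number here means that less compound is needed, a higher number that more compound is needed for the effect. Compound 1 `CCN(Cc1ccccc1)C(=O)C1CCN(S(=O)(=O)c2ccc(C(F)(F)F)nc2)CC1` carries a 6-(trifluoromethyl)pyridin-3-yl group on the sulfonyl sulfur. In this assay compound 1 gives > 10000 nM, which is a limit of the assay and not a number. Compound 2 `CCN(Cc1ccccc1)C(=O)C1CCN(S(=O)(=O)c2ccccn2)CC1` carries a pyridin-2-yl group in that place. In this assay compound 2 gives > 10000 nM, again a limit rather than a number. The step that the two limits leave unreadable from compound 1 to compound 2 therefore cannot be read, and compound 2 stands only at a limit; both values sit at the limit of > 10000 nM in this assay, at which 2 of the 2 values shown sit.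

Compound 3 `CCN(Cc1ccccc1)C(=O)C1CCN(S(=O)(=O)c2cccc3nsnc23)CC1` differs from compound 2 in one place: a group of 9 heavy atoms (6 carbon, 2 nitrogen, 1 sulfur; one five-membered aromatic ring with 3 hetero atoms, one six-membered aromatic ring of carbon only) in place of a group of 6 heavy atoms (5 carbon, 1 nitrogen; one six-membered aromatic ring with 1 hetero atom), on a sulfonyl sulfur. Among the compounds with values here, no measured step bears on this change in a readable way, since the only step available is unreadable. With both neighbours at the limit, the expectation for compound 3 in this assay rests on that limit alone. Compound 3 is expected to give 10000 nM, between 3000 nM and 30000 nM. The estimated step of a number no higher from compound 2 to compound 3 (the limit leaves the size open) is expected to lie within the scatter.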

Compound 3, half-maximal effective concentration: > 10000 nM
Compound 3: only a limit was reported (the forecaster's own chance of this, stated with the estimate: 70%); the middle value lies on the limit itself.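

In this assay compound 3 gives > 10000 nM as a limit of the assay and not a number. The steps to compound 3 from compound 1 and from compound 2 therefore cannot be read. The compounds shown leave open how much of any of the three compounds is needed for the effect, and whether their sulfonyl aryl groups differ at all.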